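From Cyano to Nitro on a Shared Core

The source may hold more compounds than are shown below. What is called first, only, known or untested is meant among the compounds shown, and "the series" means these compounds.

Of the compounds shown here, three built on a shared core have been measured in a functional assay on the whole organism (Gastrocnemius, strain Sprague-Dawley) for inhibition, with Rattus norvegicus as the target; on this read-out higher numbers stand for an effect only at larger amounts of compound and lower numbers for an effect already at smaller amounts. Compound 1 `O=C1NC(=O)N(/N=C/c2ccc(-c3ccc(Cl)c(Cl)c3)o2)C1O` gives 0.019 umol/kg. Compound 2 `N#Cc1ccc(-c2ccc(/C=N/N3C(=O)NC(=O)C3O)o2)cc1` gives 0.025 umol/kg. Compound 3 `O=C1NC(=O)N(/N=C/c2ccc(-c3cccc(C(F)(F)F)c3)o2)C1O` gives 0.096 umol/kg. Compound 2 therefore holds the middle of the three numbers, although it cannot be told apart from compound 1, since their two values lie within the usual scatter of each other. Compound 3 has the higher number than compound 2, and that gap is beyond the scatter.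

Compound 4 `O=C1NC(=O)N(/N=C/c2ccc(-c3ccc([N+](=O)[O-])cc3)o2)C1O` has not been measured yet. It is compound 2 with nitro in place of cyano on an aromatic carbon, para to a large group: nitro in place of cyano on an aromatic carbon. Among the compounds with values here, no two measured compounds differ in only one place, so no direct step shows what such a swap does. Within the data shown here, the only guide is the overall span of the measured compounds, which carry different groups and yet stay fairly close, from compound 1 at 0.019 umol/kg to compound 3 at 0.096 umol/kg. On that basis, no step beyond the scatter is expected in this assay. The expected change is small, a 1.2-fold higher number from compound 2 to compound 4 (0.08 log units; within the scatter). For compound 4 the estimated value is 0.03 umol/kg, with an expected range from 0.01 umol/kg to 0.09 umol/kg.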

Compound 4, dose for half-maximal effect: 0.015 umol/kg
Compound 4: middle estimate off by 2.0-fold (0.30 log units), on the high side; low and high end bracket the measured number.
By their numbers in this assay, from the lowest: compounds 4, 1 and 2 (each within the scatter of the next); then compound 3.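

Within the data shown here, this is the first pair in the set that differs in only one place, so it gives the first direct reading of a single swap on the shared core. In this assay, putting nitro in place of cyano on an aromatic carbon, para to a large group, gives a 1.7-fold lower number from compound 2 to compound 4 (0.22 log units; within the scatter), which means that compound 2 and compound 4 cannot be told apart on this read-out, even though nitro brings more heavy atoms and more hydrogen-bond acceptors than cyano. Nothing shown here accounts for the two groups reading alike, and no measured property of either group is available to compare them beyond their structures.

This single pair covers just two groups at one position in one whole-animal assay, so it cannot show how far the same result would extend to other kinds of group. An amine or a carboxylic acid at this same aromatic carbon would test this more sharply, since either one would show whether a group quite unlike cyano and nitro also leaves the number within the scatter of compound 2.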